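The source may report more compounds than this note shows. Statements on the series, on what has been measured and on what is new or still open speak of the compounds shown alone.

Compound 1 `O=C(c1ccccc1Cl)N1CCN(c2nc(=O)c3cc(C(F)(F)F)cc([N+](=O)[O-])c3s2)CC1`: in an ADME assay on Vero cells (Chlorocebus sabaeus) for cytotoxicity, read by MTT assay, with a stated time of 72 h (a higher number here means that more compound is tolerated, a lower number that less compound is tolerated), compound 1 gives > 125000 nM, which is a limit of the assay and not a number.
Compound 2 `O=C(C1CCCCC1)N1CCN(c2nc(=O)c3cc(C(F)(F)F)cc([N+](=O)[O-])c3s2)CC1`: in this assay compound 2 gives 88700 nM.

Compound 2 carries the only number shown in this assay; the other value is a limit (the limit of > 125000 nM in this assay, at which 1 of the 2 values shown sits). Within the data shown here, the single measured step, an at least 1.4-fold lower number from compound 1 to compound 2 (0.14 log units; that floor lies within the scatter), has a floor that lies within the scatter. Compound 3 `CC(C)(C)C1CCC(C(=O)N2CCN(c3nc(=O)c4cc(C(F)(F)F)cc([N+](=O)[O-])c4s3)CC2)CC1` differs from compound 2 by tert-butyl in place of hydrogen on a saturated ring carbon. Among the measured compounds shown here, no measured step alters a saturated ring in this way, so no step beyond the scatter is expected, though the number may again come back only as a limit. Compound 3 is expected to give 70000 nM in this assay, between 30000 nM and 140000 nM, a step of a 1.3-fold lower number from compound 2 to compound 3 (0.10 log units; within the scatter).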

Compound 3, half-maximal cytotoxic concentration: > 125000 nM
Compound 3 was reported as a limit; the forecaster's own chance of this, stated with the estimate: 30%; middle value at least 1.7-fold (0.25 log units) away from the limit.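

Placing tert-butyl on this saturated ring carbon, the first change shown at this place, does not lower the number in this assay: the result is an at least 1.4-fold higher number from compound 2 to compound 3 (0.14 log units; that floor lies within the scatter). The value of compound 3 is a limit and not a number, and it is the same limit as for compound 1: the limit of > 125000 nM in this assay, at which 2 of the 3 values shown sit. The step between those two limits cannot be read.

Open, as far as these compounds go, is how far the number for compound 3 lies past the limit. Also open, from the compounds shown here alone, is how an amine or a carboxylic acid on this ring carbon would read in this assay.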